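Swapping an Amino Ester for an Anilide

This account rests on a few compounds, and the source may have more. Where it says the series, first, only, none or still open, it means among the compounds named here.

The compounds here share one core and differ in the group carried on an amide-type nitrogen. Among the compounds with values here, compound 1 `CC[C@@H](C)[C@H](NC(=O)c1ccc(C(CC)(CC)c2ccc(OCC(O)C(C)(C)C)c(C)c2)n1CC)C(=O)OC` is the only one with a number in an assay on HL-60 cells for agonist activity at vitamin D3 receptor (Homo sapiens), read by microscopy, with a stated time of 96 h; on this read-out lower numbers stand for an effect already at smaller amounts and higher numbers for an effect only at larger amounts of compound: compound 1 gives 26 nM. Compound 2 `CCn1c(C(=O)Nc2cccc(C(F)(F)F)c2)ccc1C(CC)(CC)c1ccc(OCC(=O)C(C)(C)C)c(C)c1` returns only a limit in this assay, > 50000 nM, and so stands at the limit of > 50000 nM in this assay, at which 1 of the 2 values shown sits. Within the data shown here, compound 2 differs from compound 1 in more than one place, so no single step between the two is defined. Compound 3 `CCOc1ccc(NC(=O)c2ccc(C(CC)(CC)c3ccc(OCC(O)C(C)(C)C)c(C)c3)n2CC)cc1` is not yet measured. The change from compound 1 to compound 3 is 4-ethoxyphenyl in place of 1-(methoxycarbonyl)-2-methylbutyl on an amide-type nitrogen. Among the measured compounds shown here, with no step between measured compounds available, the size of this change is open; replacing the 1-(methoxycarbonyl)-2-methylbutyl group by 4-ethoxyphenyl is expected to weaken the effect, with the step estimated at a 9.6-fold higher number from compound 1 to compound 3 (0.98 log units; beyond the scatter). For compound 3 the expected value in this assay is 250 nM, between 30 nM and 3000 nM.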

Compound 3, half-maximal effective concentration: 630 nM
Compound 3: the middle estimate sits 2.5-fold (0.40 log units) below what was measured; the measured number falls inside the stated range.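

In this assay, the group on this amide-type nitrogen matters a great deal: replacing 1-(methoxycarbonyl)-2-methylbutyl with 4-ethoxyphenyl gives a 24-fold higher number from compound 1 to compound 3 (1.38 log units; beyond the scatter). Each group has 9 heavy atoms, so this large step comes with no change in that count, and compound 3 still gives a measured number, 630 nM. Nothing measured here explains the size of the step.

Compound 2 gives > 50000 nM, which is a limit of the assay, and it differs from compound 1 in more than one place, so no step can be read from it. The change from compound 1 to compound 3 replaces the ester and branched chain together with an aromatic ring, leaving open how a carboxylic acid in place of the methyl ester, or an unsubstituted phenyl in place of 4-ethoxyphenyl, would behave.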